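This account rests on a few compounds, and the source may have more. Where it says the series, first, only, none or still open, it means among the compounds named here.

Measured compounds:
- compound 1, `COc1ccc(-c2nn3cc(-c4cccc(N)c4)nc3s2)cc1OC`: 13000 nM
- compound 2, `Nc1cccc(-c2cn3nc(-c4ccccc4)sc3n2)c1`: 14000 nM
- compound 3, `C=C(Br)C(=O)Nc1cccc(-c2cn3nc(-c4ccc(OC)cc4)sc3n2)c1`: 890 nM

All three were tested in a functional assay on FM3A cells (Mus musculus) for inhibition, read by cell counting, with a stated time of 2 days; on this read-out lower numbers stand for stronger inhibition and higher numbers for weaker inhibition. Compound 3 stands at the lowest number of the three, and its gap to compound 1 and to compound 2 lies beyond the usual scatter of repeated measurements, so on these numbers compound 3 is the strongest inhibitor of the set.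

Compound 4, `COc1ccc(-c2nn3cc(-c4cccc(N)c4)nc3s2)cc1`, has not yet been measured in this assay. It differs from compound 3 in one place: hydrogen in place of (1-bromoethenyl)carbonyl on a nitrogen on an aromatic ring. Compound 1 and compound 2 both carry a free amino group at the same kind of position, and in this assay compound 1 gives 13000 nM while compound 2 gives 14000 nM, whereas compound 3, which carries the acyl group, gives 890 nM. On that basis the expected step from compound 3 to compound 4 in this assay is a sizeable one towards weaker inhibition, estimated as a 13-fold higher number from compound 3 to compound 4 (1.13 log units; beyond the scatter). Compound 4 is therefore expected to give about 12000 nM in this assay, within a range of 4000 nM to 30000 nM.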

Compound 4, half-maximal inhibitory concentration: 74000 nM
Compound 4: middle estimate off by 6.2-fold (0.79 log units), on the low side; the whole stated range lies below it.
By their numbers in this assay, from the lowest: compound 3; then compounds 1 and 2 (each within the scatter of the next); then compound 4.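

Taking the (1-bromoethenyl)carbonyl off the nitrogen gives an 83-fold higher number from compound 3 to compound 4 (1.92 log units; beyond the scatter) in this assay, the first direct measure of this group's worth, since the two compounds differ in that one place. The step is far larger than the gaps among the free amines, yet those gaps are real too: placing methoxy on an aromatic carbon gives a 5.3-fold higher number from compound 2 to compound 4 (0.72 log units; beyond the scatter), while replacing a methoxy with hydrogen gives a 5.7-fold higher number from compound 1 to compound 4 (0.76 log units; beyond the scatter). Compound 4 is therefore weaker than both of its amine neighbours, so methoxy groups do not shift the number in one direction across these compounds.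

An acetyl or an acryloyl group on the same nitrogen would show whether the gain depends on the bromine, the double bond or the acyl group alone. Nothing shown here explains any of these steps.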